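Aminomethyl for Phenyl on a Brominated Carboxamide Core

The compounds below may be only part of what the source reports. "The series", "measured", "known", "first", "only" and "open" are said of these compounds alone.

compound 1, `COc1cccc(CNC(=O)c2nc(Br)c3cccnc3c2N[C@H]2CC[C@H](N)CC2)c1`: 7000 nM
compound 2, `O=C(NCc1ccc(F)cc1)c1nc(Br)c2cccnc2c1NCc1ccccc1`: > 20000 nM, a limit of the assay
compound 3, `NCCCNc1c(C(=O)NCc2ccc(F)cc2)ncc2cccnc12`: 16000 nM

All three were tested in a functional assay on MDA-MB-435 cells (Homo sapiens) for cytotoxicity, read by MTT assay, with a stated time of 72 h; on this read-out lower numbers stand for stronger inhibition and higher numbers for weaker inhibition. Compound 1 gives 7000 nM and compound 3 gives 16000 nM. Compound 2 sits at the limit of > 20000 nM in this assay, at which 1 of the 3 values shown sits, which is a limit of the assay and not a number, so compound 2 stands at the weak end of what the three compounds show, with no value beyond the limit to compare against the other two.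

Compound 4, `NCCNc1c(C(=O)NCc2ccc(F)cc2)nc(Br)c2cccnc12`, has not yet been measured in this assay. It differs from compound 2 by aminomethyl in place of phenyl on a saturated chain carbon bound to a nitrogen on an aromatic ring. Among the compounds with values here, no two measured compounds differ in exactly one place, so the size of this step can only be expected, not read from the data. Compound 3, whose side chain also ends in a primary amine, gives 16000 nM, and compound 1, whose side chain carries an amine on a ring, gives 7000 nM. Both of these stand on the stronger side of what compound 2 shows. The step from compound 2 to compound 4 is therefore expected to run toward stronger inhibition, roughly an at least 2.0-fold lower number from compound 2 to compound 4 (0.30 log units; that floor lies within the scatter). Compound 4 is estimated to give 10000 nM in this assay, expected between 3000 nM and 30000 nM.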

Compound 4, half-maximal inhibitory concentration: 12000 nM
Beside the measured number, compound 4's estimate is 1.2-fold (0.08 log units) below it, and the stated range covers the measured number.
By their numbers in this assay, from the lowest: compounds 1, 4 and 3 (each within the scatter of the next, the first and the last beyond it). At a limit, above all of these: compound 2.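

In this assay, the change from benzylamino to (2-aminoethyl)amino on the shared core gives an at least 1.6-fold lower number from compound 2 to compound 4 (0.22 log units; that floor lies within the scatter). Within the data shown here, this is the first direct reading at this position, and it shows that with the 2-aminoethyl group in place of benzyl, compound 4 gives a measured number, 12000 nM, rather than a limit. Compound 2 stands at a limit of the assay and not a number, and only a floor can be stated for the step because of that limit: the limit of > 20000 nM in this assay, at which 1 of the 4 values shown sits.

Going by these compounds, it remains open whether the amine or the loss of the phenyl ring accounts for the step, and whether a plain ethyl group, a 2-hydroxyethyl group or a longer chain ending in an amine at this place would give a number like that of compound 4. Compound 3 and compound 4 differ in more than one place, so the compounds shown do not separate the length of the chain from the presence of the bromine.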